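The source may hold more compounds than are shown below. What is called first, only, known or untested is meant among the compounds shown, and "the series" means these compounds.

Measured compounds:
compound 1 `CCOC(=O)C1=C(C)N(c2ccccc2)C=CC1c1ccccc1` with -19.9%
compound 2 `CCOC(=O)C1=C(C)N(c2ccccc2)C=CC1c1ccccc1[N+](=O)[O-]` with -19.2%

In a functional assay for inhibition, using microsomes, tested at 100 ug/mL (on this read-out lower numbers stand for a stronger effect and higher numbers for a weaker effect at the one concentration tested), compound 1 gives the lowest of the two numbers, and its nearest neighbour is compound 2, with a number 0.7 percentage points higher from compound 1 to compound 2 (within the scatter). Compound 3 `COC(=O)C1=C(C)N(c2ccccc2)C=CC1c1ccccc1` differs from compound 1 by hydrogen in place of methyl on a saturated chain carbon bound to an oxygen next to a carbonyl group, so the ethoxycarbonyl becomes a methoxycarbonyl. Among the compounds with values here, no measured step touches this ester chain; the only step known, nitro for hydrogen, stayed within the scatter. He therefore expects no step beyond the scatter in this assay, with a number 0.1 percentage points lower from compound 1 to compound 3 (within the scatter) as the estimate. Compound 3 is expected to give -20%, within a range from -38% to -2%.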

Compound 3, a percentage reported as activity, at one concentration (the size of the read-out at that concentration, not a potency): -21.5%
The estimate for compound 3 lay 1.5 percentage points above the measured number; measured number inside the range.
By their numbers in this assay, from the lowest: compounds 3, 1 and 2 (each within the scatter of the next).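

In this assay, methoxycarbonyl in place of ethoxycarbonyl gives a number 1.6 percentage points lower from compound 1 to compound 3 (within the scatter). Within the data shown here, this is the first measured step at the ester chain, and it shows that removing this methyl leaves the read-out within the scatter, as the step on the aromatic carbon had done elsewhere on the molecule. No evidence bears on this result.

From the compounds shown here alone, whether a longer chain such as a butyl ester, or a carboxylic acid in place of the ester, would give a step beyond the scatter remains open.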